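Chloro to Bromo on a Spiro-Fused Chromone Series

A few compounds are considered here, and "the series" means these few. Any claim that something is new, unique, unknown or untested is made for them only; others in the source may bear on it.

Measured compounds:
Compound 1 `N#CC1=C(N)Oc2cc3oc(-c4ccccc4)cc(=O)c3c(O)c2C12C(=O)Nc1ccccc12`: 37600 nM
Compound 2 `CCN1C(=O)C2(C(C#N)=C(N)Oc3cc4oc(-c5ccc(OC)cc5OC)cc(=O)c4c(O)c32)c2cc(Cl)ccc21`: > 50000 nM

In a functional assay on A549 cells (Homo sapiens) for antiproliferative activity, read by MTT assay, with a stated time of 48 h (a higher number here means a weaker inhibitor, a lower number a stronger inhibitor), compound 1 gives 37600 nM. Compound 2 sits at a limit of this assay, > 50000 nM, so only a boundary and no number is known for it. Evidence for this boundary: the limit of > 50000 nM in this assay, at which 1 of the 2 values shown sits.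

Compound 3 `CCN1C(=O)C2(C(C#N)=C(N)Oc3cc4oc(-c5ccc(OC)cc5OC)cc(=O)c4c(O)c32)c2cc(Br)ccc21` differs from compound 2 in one place: bromo in place of chloro on an aromatic carbon. Between these two compounds no step has been measured, and no pair in this set shows how a halogen swap at this position moves the read-out. An exchange of one halogen for another of this kind is expected to give no step beyond the scatter in this assay, in either direction. Compound 3 is therefore expected to come out near 60000 nM, with a range from 30000 nM to 150000 nM, and most likely again as a limit rather than a number. The expected step from compound 2 to compound 3 is a step that the limit leaves unreadable from compound 2 to compound 3.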

Compound 3, half-maximal inhibitory concentration: > 50000 nM
Compound 3: only a limit was reported; the forecaster's own chance of this, stated with the estimate: 70%; the middle value lies beyond the limit too.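

In this assay, among the compounds shown here, compound 2 and compound 3 both sit at a limit, so no step between them can be read: the limit of > 50000 nM in this assay, at which 2 of the 3 values shown sit. The compounds shown leave open how far bromo in place of chloro on this aromatic carbon moves the half-maximal inhibitory concentration.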